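The compounds below may be only part of what the source reports. "The series", "measured", "known", "first", "only" and "open" are said of these compounds alone.

The study set out compound 1 `COc1ccc(-c2c(C)oc3c(N4CC[C@@H](NC(C)=O)C4)cc(C)nc23)cc1OC`, compound 2 `COc1ccc(-c2c(C)sc3c(N4CC[C@@H](NC(C)=O)C4)nc(C)nc23)cc1OC` and compound 3 `CC(=O)N[C@@H]1CCN(c2cc(C)nn3c(-c4ccccc4)c(C)nc23)C1`, each read in an ADME assay on microsomes from liver (Mus musculus) for metabolic stability, read by LC-MS, with NADPH named in the record, with a stated time of 60 min, tested at 1 uM, in the absence of a further agent; a lower number here means that less of the compound is left, a higher number that more of the compound is left. For compound 1 the reading in this assay is a limit of the assay rather than a number, > 95%. Compound 2 likewise reaches the limit, > 95%. Compound 3 too is reported only as the limit, > 95%. Compound 3 therefore stands where every measured compound stands, at the limit of > 95% in this assay, at which 3 of the 3 values shown sit, and nothing in the measured set separates it from compound 1 or compound 2.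

Compound 4 `CC(=O)N[C@@H]1CCN(c2cc(C)nn3c(-c4ccc5cc[nH]c5c4)c(C)nc23)C1` has not yet been measured. It differs from compound 3 in one place: 1H-indol-6-yl in place of phenyl on an aromatic carbon. Within the data shown here, no pair among the measured compounds shows a step of this kind, so the size of the step in this assay is open; the expectation is for a modest drop that may reach beyond the scatter, estimated as a number at least 10 percentage points lower from compound 3 to compound 4 (that floor lies within the scatter). For compound 4 the value expected in this assay is 85%, within a range from 55% to 95%.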

Compound 4, percent of the compound remaining: > 95%
Compound 4 ended at the assay's limit (the forecaster's own chance of this, stated with the estimate: 45%); at least 10 percentage points between middle value and limit.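

Among these compounds, compound 3 and compound 4 both reach the limit of this assay, so no step between them can be read: the limit of > 95% in this assay, at which 4 of the 4 values shown sit.

The compounds shown leave open whether 1H-indol-6-yl in place of phenyl changes the percent of compound remaining at all, and in which direction.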